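This account rests on a few compounds, and the source may have more. Where it says the series, first, only, none or still open, it means among the compounds named here.

For the measured compounds named here, compound 1 `O=C1c2c[n+]([O-])c3ccccc3c2C(=O)c2c1c1ccccc1n2Cc1cn(CC(O)CO)nn1` gives 880 nM in a functional assay on A549 cells (Homo sapiens) for cytotoxicity, read by MTT assay, with a stated time of 72 h (on this read-out lower numbers stand for stronger inhibition and higher numbers for weaker inhibition), the lowest of the two numbers known; compound 2 `CC1(C)OC[C@@H](Cn2cc(Cn3c4c(c5ccccc53)C(=O)c3c[n+]([O-])c5ccccc5c3C4=O)nn2)O1` gives 4700 nM in the same assay. Going by the values given here, the only measured step, a 5.3-fold higher number from compound 1 to compound 2 (0.73 log units; beyond the scatter), concerns the 1,2-dihydroxyethyl end of the chain and not the triazole itself. Compound 3 `O=C1c2c[n+]([O-])c3ccccc3c2C(=O)c2c1c1ccccc1n2CCN1CCCCC1` differs from compound 1 by (piperidin-1-yl)methyl in place of 1-(2,3-dihydroxypropyl)-1H-1,2,3-triazol-4-yl on a saturated chain carbon bound to an aromatic nitrogen. Among the compounds with values here, no measured step bears on this exchange, so there is no basis for expecting a shift beyond the scatter in either direction. Compound 3 is therefore estimated at 800 nM, within 250 nM to 2600 nM, a step of a 1.1-fold lower number from compound 1 to compound 3 (0.04 log units; within the scatter).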

Compound 3, half-maximal inhibitory concentration: 1080 nM
The estimate for compound 3 lay 1.4-fold (0.13 log units) below the measured number, and the stated range covers the measured number.
By their numbers in this assay, from the lowest: compounds 1 and 3 (each within the scatter of the next); then compound 2.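

In this assay the exchange of 1-(2,3-dihydroxypropyl)-1H-1,2,3-triazol-4-yl for (piperidin-1-yl)methyl gives a 1.2-fold higher number from compound 1 to compound 3 (0.09 log units; within the scatter) and so shows that this position, on a saturated chain carbon bound to an aromatic nitrogen, accepts a quite different group without a step beyond the scatter. The triazole and both hydrogen-bond donors can thus leave together, although the end of the chain mattered in compound 2. No evidence at hand explains this result. Going by these compounds, whether a longer chain bearing piperidine, or a morpholine or dimethylamine in its place, would read alike remains open.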